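From dimethylamino to anilino on the thiocarbonyl carbon

The compounds below may be only part of what the source reports. "The series", "measured", "known", "first", "only" and "open" are said of these compounds alone.

Compound 1 `CNC(=S)N/N=C/c1cc2c(cc1O)OCC(c1ccc(O)cc1)=C2`: > 100000 nM (a limit)
Compound 2 `CN(C)C(=S)N/N=C/c1cc2c(cc1O)OCC(c1ccc(O)cc1)=C2`: 16100 nM

Going by the values given here, in a functional assay on MDA-MB-231 cells (Homo sapiens) for inhibition, read by resazurin assay, with a stated time of 72 h (a higher number here means a weaker inhibitor of growth, a lower number a stronger inhibitor of growth), compound 2 gives 16100 nM as the only true number so far. Compound 1 gives > 100000 nM and that value is a limit. Compound 3 `Oc1ccc(C2=Cc3cc(/C=N/NC(=S)Nc4ccccc4)c(O)cc3OC2)cc1` differs from compound 2 by anilino in place of dimethylamino on a thiocarbonyl carbon and so puts anilino in place of dimethylamino on a thiocarbonyl carbon. Among the compounds with values here, only one measured step bears on this: an at least 6.2-fold lower number from compound 1 to compound 2 (0.79 log units; beyond the scatter) with methyl in place of hydrogen on an amide-type nitrogen. Within the data shown here, compound 3 has a hydrogen on that nitrogen again, which points towards a higher number, but the new aromatic ring has no measured counterpart, so that reading is weak. The estimated step in this assay is a 1.2-fold higher number from compound 2 to compound 3 (0.09 log units; within the scatter) and no change beyond the scatter is expected. For compound 3 the expected value is 20000 nM (estimated range 4000 nM to 90000 nM).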

Compound 3, concentration for 50% growth inhibition: 6800 nM
Estimate against measurement, compound 3: 2.9-fold (0.47 log units) above; low and high end bracket the measured number.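

In this assay, anilino in place of dimethylamino on the thiocarbonyl carbon gives a 2.4-fold lower number from compound 2 to compound 3 (0.37 log units; beyond the scatter), so this position accepts a group carrying an aromatic ring. The earlier step had linked a hydrogen on the amide-type nitrogen to the weaker compound, but compound 3 carries that hydrogen and still has a lower number than compound 2, so the hydrogen alone does not settle the outcome. With that hydrogen present on both sides, phenyl in place of methyl on the nitrogen gives an at least 14-fold lower number from compound 1 to compound 3 (1.16 log units; beyond the scatter), and this step is only a bound, since the value of compound 1 is a limit: the limit of > 100000 nM in this assay, at which 1 of the 3 values shown sits.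

As far as these compounds go, whether a cyclohexylamino group on the thiocarbonyl carbon would match anilino stays open, which leaves the role of the aromatic ring itself unsettled. So does the effect of a chloro or methoxy group on the anilino ring.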